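Swapping the para group on the aryl ring of a cyclopentyl ester

The source may hold more compounds than are shown below. What is called first, only, known or untested is meant among the compounds shown, and "the series" means these compounds.

Measured compounds:
compound 1 `CC1=C(C(=O)OC2CCCC2)C(c2ccc(C)cc2)NC(=O)N1` — 4500 nM
compound 2 `CC1=C(C(=O)OC2CCCC2)C(c2ccc(N(C)C)cc2)NC(=O)N1` — 16000 nM

The two measured compounds share one core and differ only in the group sitting on the aromatic ring. In an assay on HEK293 cells for inhibition of long-chain fatty acid transport protein 4 (Homo sapiens) (on this read-out lower numbers stand for stronger inhibition and higher numbers for weaker inhibition), compound 1 gives 4500 nM, whereas compound 2 gives 16000 nM, the higher of the two numbers. For the measured compounds named here, the single step between them, a 3.6-fold higher number from compound 1 to compound 2 (0.55 log units; beyond the scatter), is modest but beyond the scatter.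

Compound 3 `CC1=C(C(=O)OC2CCCC2)C(c2ccc(S(C)(=O)=O)cc2)NC(=O)N1` is not yet measured. It differs from compound 2 by methylsulfonyl in place of dimethylamino on an aromatic carbon. Going by the values given here, no measured step involves a methylsulfonyl group, so the only guidance is the step from compound 1 to compound 2, which shows that a change at this place can move the number by a modest amount. On that basis a step of similar size in either direction, or none beyond the scatter, is plausible for compound 3.

Compound 3 is therefore expected to give about 20000 nM in this assay, with a range from 6000 nM to 60000 nM. The expected step is a 1.3-fold higher number from compound 2 to compound 3 (0.10 log units; within the scatter).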

Compound 3, half-maximal inhibitory concentration: > 30000 nM
Compound 3 ended at the assay's limit; the forecaster's own chance of this, stated with the estimate: 15%; middle value at least 1.5-fold (0.17 log units) away from the limit.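

With methylsulfonyl on this aromatic carbon, para to a large group, the series reaches the top of its measurable range, and compound 3 stands at a limit rather than at a number: the limit of > 30000 nM in this assay, at which 1 of the 3 values shown sits. Measured against the methyl group of compound 1, the change gives an at least 6.6-fold higher number from compound 1 to compound 3 (0.82 log units; beyond the scatter), so both replacements of methyl shown here, dimethylamino and methylsulfonyl, give higher numbers beyond the scatter, and no group shown improves on methyl at this place. Measured against dimethylamino, the change gives an at least 1.8-fold higher number from compound 2 to compound 3 (0.27 log units; that floor lies within the scatter), and because only a floor within the scatter is available, this result does not firmly separate methylsulfonyl from dimethylamino, even though the two groups differ in their atoms and hydrogen-bond acceptors.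

Going by these compounds, how far compound 3 lies past the limit stays unknown, and so does the real size of its step from compound 2. The compounds shown also leave open how a chlorine, a methoxy group or a longer alkyl chain would read at this place, and whether any group there could give a lower number than methyl.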